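Amide to Sulfonamide Change on a Shared Core: Cytotoxicity Notes

The source may report more compounds than this note shows. Statements on the series, on what has been measured and on what is new or still open speak of the compounds shown alone.

Measured so far in an ADME assay on HepG2 2.2.15 cells (Homo sapiens) for cytotoxicity; a lower number here means that less compound is tolerated, a higher number that more compound is tolerated:
compound 1 `O=C(Nc1ncc(Cc2ccc(Br)cc2)s1)c1cccs1` gives > 50000 nM.
compound 2 `O=C(Nc1ncc(C(OCc2ccc(F)cc2F)c2ccccc2)s1)c1cccs1` gives "not toxic" (no number reported).
compound 3 `O=C(Nc1ncc(C(Oc2ccc3cc(Br)ccc3c2)c2ccc(Cl)cc2)s1)C1CC1` gives "not toxic" (no number reported).

The value of compound 1 is a limit of this assay and not a number; it sits at the limit of > 50000 nM in this assay, at which 1 of the 3 values shown sits. Compound 2 and compound 3 each carry an entry without a single number, so compound 3 has no numeric place among the values shown: one other value is a limit, one other entry is also without a number. No pair of these compounds differs in one place only, so no measured step exists and no size of step can be read from them.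

Compound 4 `O=S(=O)(Nc1ncc(C(Oc2ccc3cc(Br)ccc3c2)c2ccc(Cl)cc2)s1)c1ccc(Cl)cc1` is not yet measured. It differs from compound 3 in one place: (4-chlorophenyl)sulfonyl in place of cyclopropylcarbonyl on a nitrogen on an aromatic ring. With all three shown entries lying at or beyond the tolerated range, no movement beyond the scatter is expected in this assay from the change to compound 4. Compound 4 is therefore expected to give about 45000 nM, between 10000 nM and 120000 nM, most likely again reported only as a limit.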

Compound 4, half-maximal cytotoxic concentration: "not toxic" (no number reported)
The entry for compound 4 holds no number, so the estimate cannot be set against anything.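

In this assay, compound 3 and compound 4 are both entered as "not toxic" without a single number, so no step can be read for cyclopropylcarbonyl to (4-chlorophenyl)sulfonyl. The compounds shown leave open whether any member of this series would give a numeric value in this assay.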